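Benzamidomethyl replaces 4-(tert-butoxy)phenyl on the shared core

A few compounds are considered here, and "the series" means these few. Any claim that something is new, unique, unknown or untested is made for them only; others in the source may bear on it.

Compound 1 `O=[N+]([O-])c1ccc(-c2nnc(SCCCN3CCN(c4nc5ccccc5o4)CC3)o2)cc1`: 90100 nM
Compound 2 `Clc1ccc(-c2nnc(SCCCN3CCN(c4nc5ccccc5o4)CC3)o2)cc1`: 99700 nM
Compound 3 `CC(C)(C)Oc1ccc(-c2nnc(SCCCN3CCN(c4nc5ccccc5o4)CC3)o2)cc1`: 94900 nM

All three compounds were tested in a functional assay on MCF7 cells (Homo sapiens) for inhibition, read by MTT assay, with a stated time of 72 h; a lower number here means a stronger inhibitor, a higher number a weaker inhibitor. Compound 3 cannot be separated from either of the others, since a 1.1-fold higher number from compound 1 to compound 3 (0.02 log units; within the scatter) and a 1.1-fold lower number from compound 2 to compound 3 (0.02 log units; within the scatter) both lie within the scatter. The next compound to be measured is compound 4 `O=C(NCc1nnc(SCCCN2CCN(c3nc4ccccc4o3)CC2)o1)c1ccccc1`. The change is benzamidomethyl in place of 4-(tert-butoxy)phenyl on an aromatic carbon. In words, benzamidomethyl comes in place of 4-(tert-butoxy)phenyl on an aromatic carbon of a five-membered aromatic ring with 2 nitrogen and 1 oxygen.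

The closest evidence comes from the three measured exchanges. Besides the two steps above, a 1.1-fold higher number from compound 1 to compound 2 (0.04 log units; within the scatter) is also within the scatter. However, those exchanges only swap a group on the aromatic ring of the outer aryl substituent. None of them replaces the whole substituent or brings in an amide, so they offer only weak guidance here and the range must stay wide. With no measured step beyond the scatter, no shift in either direction can be argued from these data. An estimated 1.1-fold lower number from compound 3 to compound 4 (0.02 log units; within the scatter) is therefore expected, which is no step beyond the scatter. For compound 4 the expected value in this assay is 90000 nM, with an estimated range of 40000 nM to 200000 nM.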

Compound 4, half-maximal inhibitory concentration: 52700 nM
The estimate for compound 4 lay 1.7-fold (0.23 log units) above the measured number; measured number inside the range.
By their numbers in this assay, from the lowest: compounds 4, 1, 3 and 2 (each within the scatter of the next).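

In this assay, benzamidomethyl replaces the whole outer aryl substituent rather than only a group on its aromatic ring, as the earlier exchanges did, and this gives a 1.8-fold lower number from compound 3 to compound 4 (0.26 log units; within the scatter), together with a 1.9-fold lower number from compound 2 to compound 4 (0.28 log units; within the scatter) and a 1.7-fold lower number from compound 1 to compound 4 (0.23 log units; within the scatter). All three steps lie within the scatter, so this position, an aromatic carbon of a five-membered aromatic ring with 2 nitrogen and 1 oxygen, accepts a group with an amide and 1 hydrogen-bond donor without a separable shift from any of the three aryl compounds, and compound 4 cannot be ranked against them. No measurement at hand accounts for the size of these steps or links them to any property of the entering group.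

Going by these compounds, it remains open whether an amine, a carboxylic acid or a longer chain carrying the benzamide at this same position would produce a step beyond the scatter. Also open, on these data alone, is whether an exchange elsewhere on the shared core, such as a shorter or longer chain in place of the one bearing the sulfur, would separate these compounds.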